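The source may report more compounds than this note shows. Statements on the series, on what has been measured and on what is new or still open speak of the compounds shown alone.

Measured so far in a functional assay on HepG2 cells (Homo sapiens) for antiproliferative activity, read by MTT assay, with a stated time of 48 h; a higher number here means a weaker inhibitor, a lower number a stronger inhibitor:
Compound 1 `CCN(CC)CCNC(=O)c1ccc(C(CC)(CC)c2ccc(OCCC(O)(CC)CC)c(C)c2)n1CC` gives 230 nM
Compound 2 `CCn1c(C(=O)Nc2ccc(OC(F)(F)F)cc2)ccc1C(CC)(CC)c1ccc(OCCC(O)(CC)CC)c(C)c1` gives > 50000 nM, which is a limit of the assay

Compound 2 therefore stands at a limit and not at a number. Compound 3 `CCn1c(C(=O)Nc2cccc(C(F)(F)F)c2)ccc1C(CC)(CC)c1ccc(OCCC(O)(CC)CC)c(C)c1` carries 3-(trifluoromethyl)phenyl in place of 4-(trifluoromethoxy)phenyl on an amide-type nitrogen. For the measured compounds named here, the only measured step, a large one, is an at least 210-fold higher number from compound 1 to compound 2 (2.33 log units; beyond the scatter), and it came with the loss of 2-(diethylamino)ethyl, which compound 3 lacks as well. No step beyond the scatter is therefore expected in this assay, and the estimated at least 1.2-fold lower number from compound 2 to compound 3 (0.09 log units; that floor lies within the scatter) stays small. For compound 3 the expected value is 40000 nM, with an estimated range from 15000 nM to 60000 nM.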

Compound 3, half-maximal inhibitory concentration: > 50000 nM
Compound 3: only a limit was reported; the forecaster's own chance of this, stated with the estimate: 65%; middle value at least 1.2-fold (0.09 log units) away from the limit.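

In this assay compound 3 gives > 50000 nM, which is a limit of the assay and not a number. With 3-(trifluoromethyl)phenyl on the amide-type nitrogen, the change is an at least 210-fold higher number from compound 1 to compound 3 (2.33 log units; beyond the scatter), so the large loss seen with 4-(trifluoromethoxy)phenyl is not confined to that one group. The two phenyl groups cannot be ranked against each other, because both compounds stand at a limit: the limit of > 50000 nM in this assay, at which 2 of the 3 values shown sit.

Still open, from the compounds shown here alone, is whether a phenyl group carrying a dimethylamino substituent would restore activity on this nitrogen. Also open, going by these compounds, is whether a pyrrolidine or morpholine in place of the diethylamino end would stay near compound 1, which gives 230 nM.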